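Aryl Amines on a Shared Core: What Compound 4 May Give

This account rests on a few compounds, and the source may have more. Where it says the series, first, only, none or still open, it means among the compounds named here.

Compound 1 `CCCCCCCCNc1nc(SCc2ccc(C(F)(F)F)cc2)nc2ccccc12` — 13400 nM
Compound 2 `Cc1ccccc1Nc1nc(SCc2ccc(C(F)(F)F)cc2)nc2ccccc12` — 27500 nM
Compound 3 `COc1cc(Nc2nc(SCc3ccc(C(F)(F)F)cc3)nc3ccccc23)cc(OC)c1` — > 50000 nM (a limit of the assay, not a number)

Three compounds share one core and differ only in the group on a nitrogen on an aromatic ring. In a functional assay on HGC-27 cells (Homo sapiens) for cytotoxicity, read by MTT assay, with a stated time of 72 h (on this read-out lower numbers stand for stronger inhibition and higher numbers for weaker inhibition), compound 1 carries an octyl chain there and gives 13400 nM. Compound 2, with 2-methylphenyl in its place, gives 27500 nM in this assay, a change of a 2.1-fold higher number from compound 1 to compound 2 (0.31 log units; beyond the scatter). Compound 3 carries 3,5-dimethoxyphenyl and reaches only (the limit of > 50000 nM in this assay, at which 1 of the 3 values shown sits); the change from the octyl chain is an at least 3.7-fold higher number from compound 1 to compound 3 (0.57 log units; beyond the scatter), and from the 2-methylphenyl compound it is an at least 1.8-fold higher number from compound 2 to compound 3 (0.25 log units; that floor lies within the scatter). Compound 3 thus stands at the weak end of what has been measured, with no number of its own.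

Compound 4 `Fc1ccc(Nc2nc(SCc3ccc(C(F)(F)F)cc3)nc3ccccc23)cc1Cl` is not yet measured. It differs from compound 3 by 3-chloro-4-fluorophenyl in place of 3,5-dimethoxyphenyl on a nitrogen on an aromatic ring. The two aryl steps already seen point in one direction: 2-methylphenyl sits below the limit, 3,5-dimethoxyphenyl at it. Among the measured compounds shown here, a third aryl group carrying chlorine and fluorine has no direct precedent here, so compound 4 is expected to land near the other aryl compounds, as a step of an at least 1.6-fold lower number from compound 3 to compound 4 (0.22 log units; that floor lies within the scatter) in this assay. For compound 4 the estimate in this assay is 30000 nM, between 10000 nM and 60000 nM.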

Compound 4, half-maximal inhibitory concentration: 14700 nM
Beside the measured number, compound 4's estimate is 2.0-fold (0.31 log units) above it; measured number inside the range.
By their numbers in this assay, from the lowest: compounds 1, 4 and 2 (each within the scatter of the next, the first and the last beyond it). At a limit, above all of these: compound 3.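

The aryl groups on this nitrogen now separate: in this assay, 3-chloro-4-fluorophenyl in place of 3,5-dimethoxyphenyl gives an at least 3.4-fold lower number from compound 3 to compound 4 (0.53 log units; beyond the scatter), whereas the earlier step between two aryl groups had a floor that lay within the scatter. An aryl group here also need not be told apart from the octyl chain, with a 1.1-fold higher number from compound 1 to compound 4 (0.04 log units; within the scatter), and the same holds against 2-methylphenyl, with a 1.9-fold lower number from compound 2 to compound 4 (0.27 log units; within the scatter), even though compound 1 and compound 2 differ from each other beyond the scatter. The step out of compound 3 remains only a floor, since compound 3 stands at a limit of the assay and not at a number: the limit of > 50000 nM in this assay, at which 1 of the 4 values shown sits.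

As far as these compounds go, whether the chlorine, the fluorine or the two together account for the difference from 3,5-dimethoxyphenyl stays open, as does how a plain phenyl, 3-chlorophenyl or 4-fluorophenyl group would compare on this nitrogen. Also open, from the compounds shown here alone, is how a butyl chain or a benzyl group in the same place would compare with the octyl chain.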